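Shorter Aryl Amide in Place of a Peptide-like Chain

The source may report more compounds than this note shows. Statements on the series, on what has been measured and on what is new or still open speak of the compounds shown alone.

Compound 1, `Cc1cc(C)cc(S(=O)(=O)c2c(C(=O)NCc3cccc(F)c3F)[nH]c3ccc(Cl)cc23)c1`: in an ADME assay on MT4 cells (Homo sapiens) for cytotoxicity, read by MTT assay (on this read-out lower numbers stand for higher toxicity in this test and higher numbers for lower toxicity in this test), compound 1 gives > 51100 nM, which is a limit of the assay rather than a number.
Compound 2, `Cc1cc(C)cc(S(=O)(=O)c2c(C(=O)NCC(=O)NCc3ccncc3)[nH]c3ccc(Cl)cc23)c1`: compound 2 gives > 48900 nM, again a limit.
Compound 3, `Cc1cc(C)cc(S(=O)(=O)c2c(C(=O)NC(C)C(=O)NCc3ccncc3)[nH]c3ccc(Cl)cc23)c1`: compound 3 gives 19500 nM.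

Among the measured compounds shown here, compound 3 therefore stands as the only measured number among the three values; the other two sit at limits. The step of an at least 2.6-fold lower number from compound 1 to compound 3 (0.41 log units; beyond the scatter) and the step of an at least 2.5-fold lower number from compound 2 to compound 3 (0.39 log units; beyond the scatter) both bring the number down, whereas the step that the two limits leave unreadable from compound 1 to compound 2 cannot be read, since both of its values are limits.

Compound 4, `Cc1cc(C)cc(S(=O)(=O)c2c(C(=O)Nc3cc(C#N)ccn3)[nH]c3ccc(Cl)cc23)c1`, differs from compound 3 in a group of 8 heavy atoms (6 carbon, 2 nitrogen; one six-membered aromatic ring with 1 hetero atom) in place of a group of 12 heavy atoms (9 carbon, 2 nitrogen, 1 oxygen; one six-membered aromatic ring with 1 hetero atom), on an amide-type nitrogen. The change undoes the chain whose arrival lowered the number in the step of an at least 2.6-fold lower number from compound 1 to compound 3 (0.41 log units; beyond the scatter), and puts an aromatic ring back directly on the amide-type nitrogen, as in compound 1. The two readable steps were modest, so a modest move back toward a higher number is expected, with a fair chance that only a limit will be reported.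

Compound 4 is expected at 40000 nM, with a range from 15000 nM to 100000 nM. This estimate means an expected step of a 2.1-fold higher number from compound 3 to compound 4 (0.31 log units; beyond the scatter).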

Compound 4, half-maximal cytotoxic concentration: > 53700 nM
Compound 4 gave a limit, no number (the forecaster's own chance of this, stated with the estimate: 50%); middle value at least 1.3-fold (0.12 log units) away from the limit.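

In this assay, replacing the whole chain of compound 3, with its pyridine ring, by 4-cyanopyridin-2-yl on the amide-type nitrogen gives an at least 2.7-fold higher number from compound 3 to compound 4 (0.43 log units; beyond the scatter). This is new. The earlier compounds shown here showed a lower number only by adding to a chain. Here a much shorter group, with the ring set directly on the amide-type nitrogen, no longer gives a measurable number. Compound 4 stands at a limit of the assay and not at a number: the limit of > 53700 nM in this assay, at which 1 of the 4 values shown sits.

The steps linking compound 4 to compound 1 and to compound 2 cannot be read, as each joins two limits, so these three compounds cannot be ranked against one another.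

The compounds shown leave open whether the nitrile matters, which a plain pyridin-2-yl group or a 4-carboxypyridin-2-yl group on the same nitrogen would help to test. They also leave open whether the number falls further as the branch on the chain of compound 3 grows, for example with an ethyl or isopropyl group in place of the methyl.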